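The source may hold more compounds than are shown below. What is called first, only, known or untested is meant among the compounds shown, and "the series" means these compounds.

Compound 3 `COc1ccc2nc(C)cc(OCC(=O)Nc3ccc(Cl)cc3)c2c1` carries a chloro group on an aromatic carbon of the shared core. In a toxicity assay on HepG2 cells (Homo sapiens) for inhibition, read by CellTiter-Glo, with a stated time of 48 h (a lower number here means a stronger inhibitor, a higher number a weaker inhibitor), compound 3 reaches only the limit of the assay, > 100000 nM. Its two nearest relatives are compound 1 `COc1ccc2nc(C)cc(OCC(=O)Nc3ccccc3)c2c1`, which in this assay gives 39800 nM, and compound 2 `COc1ccc2nc(C)cc(OCC(=O)Nc3ccc(F)cc3)c2c1`, which in this assay gives 63100 nM. The step of a 1.6-fold higher number from compound 1 to compound 2 (0.20 log units; within the scatter) stays within the scatter, whereas an at least 2.5-fold higher number from compound 1 to compound 3 (0.40 log units; beyond the scatter) crosses it, and an at least 1.5-fold higher number from compound 2 to compound 3 (0.19 log units; that floor lies within the scatter) has a floor that lies within the scatter; the last two are bounded by the limit of > 100000 nM in this assay, at which 1 of the 3 values shown sits. Compound 4 `COc1ccc2nc(C)cc(OCC(=O)Nc3ccc(S(=O)(=O)Nc4cc(C)on4)cc3)c2c1` differs from compound 3 by (5-methyl-1,2-oxazol-3-yl)sulfamoyl in place of chloro on an aromatic carbon. Going by the values given here, none of the measured steps swaps a halogen for a group of this size, so the halogen steps give only a weak guide; they show a series whose members sit at weak inhibition throughout, with compound 3 already at the limit. Compound 4 is therefore expected to remain weak, with an expected step of a number no higher from compound 3 to compound 4 (the limit leaves the size open) that cannot be resolved against a limit. The estimate for compound 4 is 100000 nM, within a range from 30000 nM to 300000 nM, with a fair chance that this assay again reports only a limit.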

Compound 4, half-maximal inhibitory concentration: > 100000 nM
Compound 4 gave a limit, no number; the forecaster's own chance of this, stated with the estimate: 60%; the middle value lies on the limit itself.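

Going by these compounds alone, the position on the aromatic carbon that held hydrogen, fluoro or chloro in the earlier compounds also accepts (5-methyl-1,2-oxazol-3-yl)sulfamoyl, a far larger group with a five-membered aromatic ring of its own, and in this assay this change brings no measurable inhibition back. Measured against the smaller relatives, the change gives an at least 2.5-fold higher number from compound 1 to compound 4 (0.40 log units; beyond the scatter) and an at least 1.5-fold higher number from compound 2 to compound 4 (0.19 log units; that floor lies within the scatter), and only the first of these floors clears the scatter. The step between compound 3 and compound 4 cannot be read, and the earlier halogen steps could not show that two such different groups would end at one and the same limit: the limit of > 100000 nM in this assay, at which 2 of the 4 values shown sit.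

The compounds shown leave open how far compound 3 and compound 4 really lie beyond that limit, and so whether the two differ at all. They also leave open whether an amine, a carboxylic acid or a longer chain at this place would give a number that can be read, or one that lies on the stronger side of compound 1.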